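The compounds below may be only part of what the source reports. "The series", "measured", "known", "first", "only" and "open" are said of these compounds alone.

Measured in a functional assay on ECa-109 cells for inhibition, with ECa-109 cell line (Homo sapiens) as the target, read by sulforhodamine B assay; a lower number here means a stronger inhibitor, a higher number a weaker inhibitor:
- compound 1 `CCc1ccc(NC2=CC(=O)c3nc4n(c3C2=O)[C@H]2OC[C@@H](O)[C@H]2OC4)cc1`: 3080 nM
- compound 2 `COc1ccccc1NC1=CC(=O)c2nc3n(c2C1=O)[C@H]1OC[C@@H](O)[C@H]1OC3`: > 4000 nM (a limit)
- compound 3 `CCOc1ccccc1NC1=CC(=O)c2nc3n(c2C1=O)[C@H]1OC[C@@H](O)[C@H]1OC3`: 4630 nM

Compound 2 stands at the limit of > 4000 nM in this assay, at which 1 of the 3 values shown sits, so its entry is a limit and not a number. The next compound to read is compound 4 `O=C1C=C(N2CCCCC2)C(=O)c2c1nc1n2[C@H]2OC[C@@H](O)[C@H]2OC1`, with piperidin-1-yl in place of (2-methoxyphenyl)amino on a double-bonded ring carbon. Among the measured compounds shown here, two measured steps bear on this only indirectly, as both keep an aromatic group on the amine nitrogen: an at least 1.2-fold higher number from compound 1 to compound 2 (0.11 log units; that floor lies within the scatter) and a 1.5-fold higher number from compound 1 to compound 3 (0.18 log units; within the scatter). Both lie within the scatter. The step that the limit leaves unreadable from compound 2 to compound 3 adds nothing. For the measured compounds named here, no measured step replaces the whole group, so no step beyond the scatter is expected: the expected step is a number no higher from compound 2 to compound 4 (the limit leaves the size open). For compound 4 the estimated value is 4000 nM, with an expected range of 1300 nM to 12000 nM.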

Compound 4, half-maximal inhibitory concentration: > 8000 nM
Compound 4: a limit, no number; the forecaster's own chance of this, stated with the estimate: 30%; middle value at least 2.0-fold (0.30 log units) away from the limit.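

Compound 4 carries a limit and not a number: the limit of > 8000 nM in this assay, at which 1 of the 4 values shown sits.

In this assay, among the compounds shown here, piperidin-1-yl in place of (4-ethylphenyl)amino gives an at least 2.5-fold higher number from compound 1 to compound 4 (0.41 log units; beyond the scatter), the first step at this position to lie beyond the scatter, and this change removes both the aromatic ring and the hydrogen-bond donor. The steps from compound 2 cannot be read, as its entry is also a limit.

Which of these two losses matters remains open. A cyclohexylamino group on the same double-bonded ring carbon would keep the donor without the aromatic ring.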